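Acetamidomethyl on the shared core: expectation for compound 4

This account rests on a few compounds, and the source may have more. Where it says the series, first, only, none or still open, it means among the compounds named here.

In a functional assay with Oryctolagus cuniculus as the target (on this read-out lower numbers stand for stronger inhibition and higher numbers for weaker inhibition), compound 1 `CNC(=N)Nc1nc(-c2ccc(OC)cc2)c(-c2ccc(OC)cc2)s1` gives 62 nM and compound 2 `COc1ccc(-c2nc(/N=C(\N)N(C)C)sc2-c2ccc(OC)cc2)cc1` gives 37 nM. Compound 3 `COc1ccc(-c2nc(/N=C(\N)n3ccnc3)sc2-c2ccc(OC)cc2)cc1` gives > 100 nM, which is a limit of the assay and not a number. Its place in the series is thus (the limit of > 100 nM in this assay, at which 1 of the 3 values shown sits).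

The change to compound 4 `COc1ccc(-c2nc(CNC(C)=O)sc2-c2ccc(OC)cc2)cc1` is a group of 5 heavy atoms (3 carbon, 1 nitrogen, 1 oxygen; no ring) in place of a group of 8 heavy atoms (4 carbon, 4 nitrogen; one five-membered aromatic ring with 2 hetero atoms), on an aromatic carbon. The measured steps at this same carbon are a 1.7-fold lower number from compound 1 to compound 2 (0.22 log units; within the scatter), an at least 1.6-fold higher number from compound 1 to compound 3 (0.20 log units; that floor lies within the scatter) and an at least 2.7-fold higher number from compound 2 to compound 3 (0.43 log units; beyond the scatter). None of them brings in acetamidomethyl, and compound 3 offers only a limit to step from. These steps therefore show the spread among the three groups tried, not the effect of this replacement. No step beyond the scatter is expected in this assay, and no direction is favoured. The expected step is a number no higher from compound 3 to compound 4 (the limit leaves the size open). The estimate for compound 4 is 100 nM, with an expected range from 25 nM to 400 nM.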

Compound 4, half-maximal inhibitory concentration: 15 nM
Estimate against measurement, compound 4: 6.7-fold (0.82 log units) above; the whole stated range lies above it.
By their numbers in this assay, from the lowest: compound 4; then compounds 2 and 1 (each within the scatter of the next). At a limit, above all of these: compound 3.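

In this assay, going by these compounds alone, the aromatic carbon next to the ring nitrogen and next to the ring sulfur now gives a lower number beyond the scatter, which no earlier pair showed: acetamidomethyl brings a 2.5-fold lower number from compound 2 to compound 4 (0.39 log units; beyond the scatter) and a 4.1-fold lower number from compound 1 to compound 4 (0.62 log units; beyond the scatter) on the shared core. The 3 nitrogen atoms of the groups in compound 1 and compound 2 are thus not needed at this carbon, and the step of an at least 6.6-fold lower number from compound 3 to compound 4 (0.82 log units; beyond the scatter) gives only a floor for its size. The value of compound 3 is a limit of the assay and not a number: the limit of > 100 nM in this assay, at which 1 of the 4 values shown sits.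

Open, going by these compounds, is whether an aminomethyl group, a carboxylic acid or a longer chain at this carbon would match compound 4. Also open, on these data alone, is whether the carbonyl or the amide hydrogen of acetamidomethyl matters for this step.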